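The compounds below may be only part of what the source reports. "The series", "measured", "known", "first", "only" and "open" are said of these compounds alone.

Compound 1 `CC(C)[C@H](C(=O)NCc1ccccc1)c1ccc(Cl)cc1` carries an amide whose nitrogen bears a benzyl group. In a functional assay on CHO cells for agonist activity at Free fatty acid receptor 2 (Homo sapiens), read by cAMP accumulation (a lower number here means a smaller maximal response, a higher number a larger maximal response), compound 1 gives < 30%, which is a limit of the assay rather than a measured number (the limit of < 30% in this assay, at which 1 of the 2 values shown sits). Compound 2 `CC(C)[C@H](C(=O)Nc1nc(C(C)(C)C)cs1)c1ccc(Cl)cc1` gives 45% in this assay. Compound 3 `CC(C)[C@H](C(=O)Nc1ncc(C#N)s1)c1ccc(Cl)cc1` differs from compound 1 by one change (5-cyano-1,3-thiazol-2-yl in place of benzyl on an amide-type nitrogen). Among the measured compounds shown here, no single-change step between measured compounds is available, so the expected step of a number at least 10 percentage points higher from compound 1 to compound 3 (that floor lies within the scatter) is an upward one, guided by compound 2 and its 45%. Compound 3 is therefore expected to reach 40%, within 15% to 65%.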

Compound 3, largest response reached (reported as efficacy), in percent of the reference or control that the assay uses: 105%
Compound 3: the middle estimate sits 65 percentage points below what was measured, outside the stated range (above it).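

The group on the amide-type nitrogen can decide the maximal response in this assay: putting 5-cyano-1,3-thiazol-2-yl in place of benzyl gives a number at least 75 percentage points higher from compound 1 to compound 3 (beyond the scatter), with the rest of the molecule unchanged. Both groups hold the same number of heavy atoms, so this step comes without any change in that count. Compound 1 stands at a limit of the assay, so the step is known only as a minimum: the limit of < 30% in this assay, at which 1 of the 3 values shown sits.

The compounds shown do not separate the contribution of the nitrile from that of the ring carrying it. An amine or a carboxylic acid in place of the nitrile would address that question.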